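A Nitro Group in Place of Trifluoromethyl

This account rests on a few compounds, and the source may have more. Where it says the series, first, only, none or still open, it means among the compounds named here.

Three compounds were measured in an assay on CHO cells for binding affinity to metabotropic glutamate receptor 2 (Rattus norvegicus); a higher number here means a weaker inhibitor, a lower number a stronger inhibitor:
compound 1, `CCC(C)O[C@@H]1C[C@@H]2[C@H]([C@]1(N)C(=O)O)[C@@]2(F)C(=O)O`, gives 6.68 nM
compound 2, `N[C@]1(C(=O)O)[C@H]2[C@@H](C[C@H]1OCCCc1ccccc1)[C@]2(F)C(=O)O`, gives 9.83 nM
compound 3, `N[C@]1(C(=O)O)[C@H]2[C@@H](C[C@H]1OCc1cccc(C(F)(F)F)c1)[C@]2(F)C(=O)O`, gives 5.72 nM

Compound 3 has the lowest of the three numbers in this assay, but its gap to compound 1 and its gap to compound 2 both lie within the usual scatter of repeated measurements, so the three compounds cannot be placed in an order on these data. The ether side chain is the only part that varies across the set, and none of the three side chains moves the number beyond the scatter.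

Compound 4, `N[C@]1(C(=O)O)[C@H]2[C@@H](C[C@H]1OCc1cccc([N+](=O)[O-])c1)[C@]2(F)C(=O)O`, has not yet been measured. It differs from compound 3 in one place: nitro in place of trifluoromethyl on an aromatic carbon. The three measured side chains, from a branched alkyl to a phenylpropyl to a substituted benzyl, leave the number unchanged within the scatter. Within the data shown here, there is no measured step here that would point in either direction for this change. The expected step from compound 3 to compound 4 is therefore a 1.2-fold higher number from compound 3 to compound 4 (0.09 log units; within the scatter), meaning no change beyond the scatter. Compound 4 is estimated to give 7 nM in this assay, with a range from 3 nM to 16 nM.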

Compound 4, inhibition constant: 7.87 nM
Compound 4: middle estimate off by 1.1-fold (0.05 log units), on the low side; measured number inside the range.
By their numbers in this assay, from the lowest: compounds 3, 1, 4 and 2 (each within the scatter of the next).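

In this assay, among these compounds, nitro in place of trifluoromethyl on an aromatic carbon gives a 1.4-fold higher number from compound 3 to compound 4 (0.14 log units; within the scatter), the first step in this set between two compounds that differ in one place. The earlier compounds shown here differ across the whole ether side chain and could say nothing about a single group on the aromatic ring, whereas this pair isolates one carbon of that ring, meta to a large group. There, trifluoromethyl, with 4 heavy atoms and 0 hydrogen-bond acceptors, and nitro, with 3 heavy atoms and 2 hydrogen-bond acceptors, are not told apart by this measurement, and no independent measurement is available to explain that result.

From the compounds shown here alone, whether an amine or a carboxylic acid on the same aromatic carbon would also stay within the scatter remains open, as does whether nitro would do so on another carbon of the ring. The compounds shown also include no ether side chain that moves the number beyond the scatter, so they do not reveal which groups, if any, this part of the structure would fail to tolerate.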